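Nitro removal on the anilino ring of compound 2

The compounds below may be only part of what the source reports. "The series", "measured", "known", "first", "only" and "open" are said of these compounds alone.

Measured so far:
compound 1, `N#CC1=C(NCC(=O)O)N(c2ccccc2)C(=O)N2CCCCC(N3CCCC3)C12`: 67.2%
compound 2, `N#CC1=C(/N=C/Nc2ccc([N+](=O)[O-])cc2)N(c2ccccc2)C(=O)N2CCCCC(N3CCCC3)C12`: 32.1%

In a functional assay on the whole organism (strain albino) for inhibition, with Rattus norvegicus as the target, read by paw edema, with a stated time of 1 h, at a dose of 20 mmol/kg by the intraperitoneal route (on this read-out lower numbers stand for less inhibition and higher numbers for more inhibition at the one dose given (going by the name of the read-out)), compound 1 gives 67.2% and compound 2 gives 32.1%, the lower of the two numbers, set apart by a number 35.1 percentage points lower from compound 1 to compound 2 (beyond the scatter). Compound 3, `N#CC1=C(/N=C/Nc2ccccc2)N(c2ccccc2)C(=O)N2CCCCC(N3CCCC3)C12`, differs from compound 2 by hydrogen in place of nitro on an aromatic carbon, that is 4-nitrophenyl to phenyl. Going by the values given here, the one measured step exchanges the whole group on the double-bonded ring carbon and leaves the nitro untouched, so no measured step bears on this change. The step to compound 3 is expected to be a number 3.9 percentage points higher from compound 2 to compound 3 (within the scatter), not beyond the scatter. Compound 3 is estimated at 36%, between 15% and 58%.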

Compound 3, a percentage reported as inhibition, in the whole organism at one dose (the size of the read-out at that dose, not a potency): 35.2%
Compound 3: middle estimate off by 0.8 percentage points, on the high side, within the range that was stated.
By their numbers in this assay, from the lowest: compounds 2 and 3 (each within the scatter of the next); then compound 1.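

In this assay, nitro and hydrogen on this aromatic carbon are not told apart: a number 3.1 percentage points higher from compound 2 to compound 3 (within the scatter). With the nitro gone, the exchange on the double-bonded ring carbon still gives a number 32 percentage points lower from compound 1 to compound 3 (beyond the scatter), so the gap to compound 1 does not depend on the nitro. No data on hand explain either step.

Open, as far as these compounds go, is whether an amine or a methoxy group on this aromatic carbon would read differently from nitro and hydrogen. Also open, from the compounds shown here alone, is whether a carboxylic acid on the anilino ring would bring the number back towards that of compound 1.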